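Swapping a Naphthyl for a Dimethoxyphenyl on a Weak Inhibitor

A few compounds are considered here, and "the series" means these few. Any claim that something is new, unique, unknown or untested is made for them only; others in the source may bear on it.

Measured so far:
compound 1, `COc1nc(-c2cc3ccccc3o2)cc(-c2cccc3ccccc23)c1C#N`, 359000 nM;
compound 2, `CCOc1nc(-c2cc3ccccc3o2)cc(-c2ccc3ccccc3c2)c1C#N`, 423000 nM;
compound 3, `COc1ccc(-c2cc(-c3cc4ccccc4o3)nc(OC)c2C#N)cc1`, 262000 nM.

All three were tested in a functional assay on aorta (strain Wistar) for inhibition, with Thoracic aorta (Rattus norvegicus) as the target; a lower number here means a stronger inhibitor, a higher number a weaker inhibitor. The three numbers lie within the usual scatter of one another, so compound 2 cannot be set apart from compound 1 or compound 3; all three are weak inhibitors. Compound 4, `CCOc1nc(-c2cc3ccccc3o2)cc(-c2cc(OC)ccc2OC)c1C#N`, has not been measured. It differs from compound 2 in one place: 2,5-dimethoxyphenyl in place of naphthalen-2-yl on an aromatic carbon, on an aromatic carbon ortho to a cyano group and opposite the ring nitrogen. Compound 3, which also carries a methoxy-bearing phenyl, gives 262000 nM. Compound 4 is therefore expected to stay in the same weak range, with a step of a 1.4-fold lower number from compound 2 to compound 4 (0.15 log units; within the scatter) that is not beyond the scatter. The estimate for compound 4 is 300000 nM, between 120000 nM and 750000 nM.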

Compound 4, half-maximal inhibitory concentration: 327000 nM
For compound 4 the middle estimate is 1.1-fold (0.04 log units) below the measured one; low and high end bracket the measured number.
By their numbers in this assay, from the lowest: compounds 3, 4, 1 and 2 (each within the scatter of the next).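

Replacing naphthalen-2-yl with 2,5-dimethoxyphenyl, on the aromatic carbon ortho to a cyano group, gives a 1.3-fold lower number from compound 2 to compound 4 (0.11 log units; within the scatter) in this assay. At this position, then, losing one aromatic carbon ring and gaining hydrogen-bond acceptors leaves compound 4 indistinguishable from compound 2, and both remain weak inhibitors. No independent measurement is available to explain this result.

As far as these compounds go, it remains open whether a group of a different kind here, such as an amine or a carboxylic acid, would move the number beyond the scatter.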